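Methyl in Place of Bromo on Two Different Cores

The source may report more compounds than this note shows. Statements on the series, on what has been measured and on what is new or still open speak of the compounds shown alone.

Of the compounds shown here, three have been measured in a functional assay on MOLT-4 cells (Homo sapiens) for inhibition; on this read-out lower numbers stand for stronger inhibition and higher numbers for weaker inhibition. Compound 1 `O=C1/C(=C/c2ccc(Br)cc2)Cc2ccccc21` gives only a limit, > 500000 nM. Compound 2 `Cc1ccc(/C=C2\Cc3ccccc3C2=O)cc1` likewise gives only a limit, > 500000 nM. Compound 3 `O=C1/C(=C/c2cccc(Br)c2)CCCc2ccccc21` gives 17100 nM.

The change from compound 1 to compound 2 is methyl in place of bromo on an aromatic carbon. Its step, a step that the two limits leave unreadable from compound 1 to compound 2, cannot be read, because both compounds sit at the limit of > 500000 nM in this assay, at which 2 of the 3 values shown sit. Compound 3 is the only one of the three with a number in this assay; how its core differs from that of compound 1 is not broken down here.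

Compound 4 `Cc1cccc(/C=C2\CCCc3ccccc3C2=O)c1` is not yet measured. It differs from compound 3 by methyl in place of bromo on an aromatic carbon. For the measured compounds named here, this is the same kind of change as the one from compound 1 to compound 2, but not the same: there the methyl stands para to a large group, here it stands meta to a large group. The measured pair gives no readable size for such a step, so the expectation for compound 4 rests on compound 3 alone, which gives 17100 nM, and on the exchange of one heavy atom for another with no change in ring count, donors, acceptors or charge. On that basis a step of a 1.5-fold higher number from compound 3 to compound 4 (0.16 log units; within the scatter) is expected. Compound 4 is estimated at 25000 nM in this assay, with a range expected from 8000 nM to 80000 nM.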

Compound 4, half-maximal inhibitory concentration: 34600 nM
Compound 4: the middle estimate sits 1.4-fold (0.14 log units) below what was measured; the measured number falls inside the stated range.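

In this assay the exchange of bromo for methyl on an aromatic carbon of the core of compound 3 comes out as a 2.0-fold higher number from compound 3 to compound 4 (0.31 log units; beyond the scatter), so on this core the change has a readable size, and it runs towards weaker inhibition. The same kind of change on the core of compound 1 cannot be read, because compound 1 and compound 2 both stand at a limit of the assay and not at a number: the limit of > 500000 nM in this assay, at which 2 of the 4 values shown sit. The series therefore holds one readable step for this change, which shows what it does on one core but not whether its size or direction carries over to the other, and the two pairs also differ in where the group stands on the ring.

The compounds shown leave open how a group other than bromo or methyl, such as an amine, a carboxylic acid or a longer chain, would read at this place on the core of compound 3. They also leave open whether any compound on the core of compound 1 can give a number rather than a limit in this assay, which a true comparison of the two cores would need.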